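A few compounds are considered here, and "the series" means these few. Any claim that something is new, unique, unknown or untested is made for them only; others in the source may bear on it.

Working notes on the series. Compound 1 `Cc1ccc2c(NCc3ccco3)nc(NC(C)C)nc2c1` and compound 3 `COc1ccc2c(NCc3ccco3)nc(NC(C)C)nc2c1` share a core; in a physicochemical assay for lipophilicity, at pH 3 (a higher number here means a more lipophilic compound, a lower number a more polar compound), compound 1 gives 1.58 and compound 3 gives 3.11. Among the measured compounds shown here, the single change between them, (methoxy in place of methyl on an aromatic carbon), produced a number 1.53 log units higher from compound 1 to compound 3 (beyond the scatter). Compound 2 `Cc1ccc2nc(NC(C)C)nc(NCc3ccco3)c2c1` holds the same atoms joined differently; the difference between the two cores is not broken down here. In this assay compound 2 gives 1.55.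

Compound 4 `COc1ccc2nc(NC(C)C)nc(NCc3ccco3)c2c1` is not yet measured in this assay. It differs from compound 2 by methoxy in place of methyl on an aromatic carbon, the same change already made from compound 1 to compound 3. On the strength of that one precedent, compound 4 is expected to show a number 1.50 log units higher from compound 2 to compound 4 (beyond the scatter) in this assay, a step close to the earlier one, because compound 3 gave 3.11 against compound 1. Compound 4 is thus estimated at 3.05, between 2.5 and 3.6, pending measurement.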

Compound 4, distribution coefficient: 2.95
The estimate for compound 4 lay 0.10 log units above the measured number; low and high end bracket the measured number.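

In this assay methoxy in place of methyl on an aromatic carbon gives a number 1.40 log units higher from compound 2 to compound 4 (beyond the scatter) and, on the other core, a number 1.53 log units higher from compound 1 to compound 3 (beyond the scatter). Both steps are large and run in the same direction, so the change carries over between these two cores, but two pairs show nothing about any other core in the series. Nothing given here bears on the origin of either step.

Still open, on these data alone, is whether an amine, a carboxylic acid or a longer alkoxy chain in place of methyl would give a step of similar size on both cores. Also open, as far as these compounds go, is whether the methoxy step would persist with another group in place of the furan-bearing amine.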